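Isobutyl for cyclopropylamino on the shared core

This account rests on a few compounds, and the source may have more. Where it says the series, first, only, none or still open, it means among the compounds named here.

Compound 1 `CCn1c(NC2CC2)nc2ccsc2c1=O` carries a cyclopropylamino group on its core. In an assay on cells for inhibition of high affinity 3',5'-cyclic-AMP phosphodiesterase 7A (Homo sapiens), read by scintillation counting and cAMP accumulation, with a stated time of 30 min (a higher number here means a weaker inhibitor, a lower number a stronger inhibitor), compound 1 gives 2600 nM, the higher of the two numbers recorded so far. Going by the values given here, the only other measured compound, compound 2 `CCn1c(NC(C)C)nc2c(C3CCN(C(=O)c4ccccc4)C3)csc2c1=O`, differs in more than one place and gives 1.5 nM in this assay, a gap far beyond the scatter; no single step links the two, so their values are noted side by side and nothing more is drawn from them.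

Compound 3 `CCn1c(CC(C)C)nc2ccsc2c1=O` is the unmeasured analogue of compound 1. The change, (isobutyl in place of cyclopropylamino on an aromatic carbon), removes the only hydrogen-bond donor and acceptor of that group. Among the compounds with values here, no measured pair isolates such a change here. The expectation is a modest step toward a weaker inhibitor, a 2.3-fold higher number from compound 1 to compound 3 (0.36 log units; beyond the scatter), with a fair chance that it stays within the scatter. Compound 3 is estimated at 6000 nM in this assay, within 1500 nM to 25000 nM.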

Compound 3, half-maximal inhibitory concentration: 4700 nM
Compound 3: the middle estimate sits 1.3-fold (0.11 log units) above what was measured; low and high end bracket the measured number.
By their numbers in this assay, from the lowest: compound 2; then compounds 1 and 3 (each within the scatter of the next).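

In this assay, isobutyl in place of cyclopropylamino on an aromatic carbon gives a 1.8-fold higher number from compound 1 to compound 3 (0.26 log units; within the scatter), so at this place on the shared core the two groups cannot be told apart. Cyclopropylamino brings a hydrogen-bond donor, a hydrogen-bond acceptor and a three-membered ring, and isobutyl brings none of these, yet this exchange produces no reading beyond the scatter. Nothing at hand bears on why the two numbers lie so close.

Going by these compounds, whether a carboxylic acid or a longer chain at this place would also stay within the scatter of compound 1 remains open. Going by these compounds alone, compound 2, at 1.5 nM, differs from the other compounds in more than one place, so no single step yet connects its number to this position.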